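A few compounds are considered here, and "the series" means these few. Any claim that something is new, unique, unknown or untested is made for them only; others in the source may bear on it.

Measured compounds:
compound 1, `Cc1ccc(S(=O)(=O)/N=C(/CCNC2=CC(=O)c3ccccc3C2=O)Nc2cccc(C(F)(F)F)c2)cc1`, 89100 nM in a functional assay on MCF7 cells (Homo sapiens) for cytotoxicity, read by MTT assay, with a stated time of 48 h; on this read-out lower numbers stand for stronger inhibition and higher numbers for weaker inhibition
compound 2, `COc1ccc(N/C(CCNC2=CC(=O)c3ccccc3C2=O)=N\S(=O)(=O)c2ccc(C)cc2)cc1OC`, 12300 nM in this assay

Going by the values given here, compound 2 stands at the lowest of the two numbers so far; the only other compound, compound 1, gives a number that is higher by a 7.2-fold lower number from compound 1 to compound 2 (0.86 log units; beyond the scatter), a step beyond the scatter, brought about by putting 3,4-dimethoxyphenyl in place of 3-(trifluoromethyl)phenyl on the amine nitrogen. Compound 3, `Cc1ccc(S(=O)(=O)/N=C(/CCNC2=CC(=O)c3ccccc3C2=O)NC2CCCCC2)cc1`, is not yet measured. It differs from compound 2 by cyclohexyl in place of 3,4-dimethoxyphenyl on an amine nitrogen. Among the compounds with values here, only one measured step bears on this change, and only loosely: the step from compound 1 to compound 2 exchanged one aromatic ring for another on the same nitrogen, whereas here the aromatic ring gives way to a saturated one, a kind of exchange for which no measured pair exists. The one step shown says that what sits on this nitrogen can move the number by a modest but real amount. Within the data shown here, with no closer precedent, a step in the direction of a higher number, of a size comparable to the one measured step, is estimated as a 2.4-fold higher number from compound 2 to compound 3 (0.39 log units; beyond the scatter). Compound 3 is therefore expected to give 30000 nM, within a range from 8000 nM to 120000 nM.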

Compound 3, half-maximal inhibitory concentration: 7580 nM
Beside the measured number, compound 3's estimate is 4.0-fold (0.60 log units) above it, and the stated range ends above it.
By their numbers in this assay, from the lowest: compounds 3 and 2 (each within the scatter of the next); then compound 1.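

In this assay, the aromatic 3,4-dimethoxyphenyl and the saturated cyclohexyl on the amine nitrogen cannot be told apart (a 1.6-fold lower number from compound 2 to compound 3 (0.21 log units; within the scatter)), so among these compounds an aromatic ring on this nitrogen is not needed to reach this level. The step from the 3-(trifluoromethyl)phenyl compound is of a different order (a 12-fold lower number from compound 1 to compound 3 (1.07 log units; beyond the scatter)), which leaves compound 1 as the weakest of the three; since aromatic rings now stand on both sides of that gap, the division on this nitrogen is not simply aromatic against saturated, and compound 2 is the case that goes against such a reading. Nothing given here accounts for why the 3-(trifluoromethyl)phenyl group stands apart from the other two.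

The compounds shown leave open whether a ring on this nitrogen is needed at all, as an open chain such as n-butyl would show, and whether a smaller saturated ring such as cyclopropyl or a ring carrying an amine, such as piperidin-4-yl, would keep the number at this level. They also leave open how far the number moves with changes elsewhere on the shared core, since all three compounds keep it unchanged.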